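This account rests on a few compounds, and the source may have more. Where it says the series, first, only, none or still open, it means among the compounds named here.

Compound 1 `C/N=C(\S)NCCCCCn1nc(-c2ccccc2)ccc1=O` gives 68.9% in a functional assay on the whole organism with Rattus norvegicus as the target, at a dose of 100 mg/kg; on this read-out lower numbers stand for less inhibition and higher numbers for more inhibition at the one dose given (going by the name of the read-out).
Compound 2 `CC/N=C(\S)NCCCCCn1nc(-c2ccccc2)ccc1=O` gives 66.4% in this assay.
Compound 3 `CC/N=C(/NC#N)NCCCCn1nc(-c2ccccc2)c(C)cc1=O` gives 38.8% in this assay.

Compound 4 `C/N=C(/NC#N)NCCCCn1nc(-c2ccccc2)c(C)cc1=O` has not yet been measured. It differs from compound 3 by one change, (hydrogen in place of methyl on a saturated chain carbon bound to a double-bonded nitrogen). The same change has already been measured once among these compounds, from compound 2 to compound 1, where it reads (hydrogen in place of methyl on a saturated chain carbon bound to a double-bonded nitrogen). In this assay it made a number 2.5 percentage points higher from compound 2 to compound 1 (within the scatter), so the two values stand within the usual scatter of each other and nothing can be said about a direction. The two cores, that of compound 2 and that of compound 3, are not the same, and the difference between them is not broken down here. Compound 3 stands well apart from compound 1 and compound 2 in this assay, with both of those values beyond the scatter from it, but that gap comes with the change of core, not with the change to be made now. Because the measured step of a number 2.5 percentage points higher from compound 2 to compound 1 (within the scatter) stayed within the scatter, a step of similar size is expected from compound 3 to compound 4, about a number 1.2 percentage points higher from compound 3 to compound 4 (within the scatter). Compound 4 is therefore estimated at 40%, with a likely range from 28% to 53%, resting on one measured pair alone.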

Compound 4, a percentage reported as inhibition, in the whole organism at one dose (the size of the read-out at that dose, not a potency): 46.4%
Beside the measured number, compound 4's estimate is 6.4 percentage points below it; the measured number falls inside the stated range.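

In this assay, putting hydrogen in place of methyl on a saturated chain carbon bound to a double-bonded nitrogen, which turns ethyl into methyl, gives a number 7.6 percentage points higher from compound 3 to compound 4 (within the scatter). Set beside the earlier case, the change reads alike on the two cores: the same change on two cores in this assay, a number 2.5 percentage points higher (within the scatter) from compound 2 to compound 1 and a number 7.6 percentage points higher (within the scatter) from compound 3 to compound 4, 5.1 percentage points apart, within the scatter of two such steps. So on both cores this small edit stays within the normal noise of the measurement, which fits the idea that it carries over from one core to the other with little consequence, but two pairs cannot prove that it has no effect, cannot give it a direction, and say nothing about cores outside these compounds.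

The compounds shown leave open whether a longer chain such as propyl or butyl, or an amine, at this place would move the number beyond the scatter. They also leave open which of the several differences between the core of compound 2 and the core of compound 3 goes with the gap between those two compounds.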